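Thiophen-2-yl in place of 4-methylphenyl on compound 3

A few compounds are considered here, and "the series" means these few. Any claim that something is new, unique, unknown or untested is made for them only; others in the source may bear on it.

In a functional assay on HeLa cells (Homo sapiens) for antiproliferative activity, read by MTT assay, with a stated time of 48 h (on this read-out higher numbers stand for weaker inhibition and lower numbers for stronger inhibition), compound 1 `Cn1cc(-c2cnc3ccc(N)nc3c2)cn1` gives only a limit, > 50000 nM. Compound 2 `Cn1cc(-c2cnc3ccc(NS(=O)(=O)c4ccc(C(F)(F)F)cc4)nc3c2)cn1` also gives only a limit, > 50000 nM. Compound 3 `Cc1ccc(S(=O)(=O)Nc2ccc3ncc(-c4cnn(C)c4)cc3n2)cc1` stands at a limit too, > 50000 nM, and not at a number. What is known so far is the limit of > 50000 nM in this assay, at which 3 of the 3 values shown sit. Compound 4 `Cn1cc(-c2cnc3ccc(NS(=O)(=O)c4cccs4)nc3c2)cn1` carries thiophen-2-yl in place of 4-methylphenyl on a sulfonyl sulfur. Going by the values given here, the only measured step that bears on this swap is a step that the two limits leave unreadable from compound 2 to compound 3, so it offers no size to carry over. The estimate means a number no higher from compound 3 to compound 4 (the limit leaves the size open), so no step beyond the scatter is expected in this assay. For compound 4 the estimated value is 50000 nM, with an expected range of 20000 nM to 100000 nM.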

Compound 4, half-maximal inhibitory concentration: 38400 nM
The estimate for compound 4 lay 1.3-fold (0.11 log units) above the measured number; measured number inside the range.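

In this assay, thiophen-2-yl in place of 4-methylphenyl on the sulfonyl sulfur gives the first measured number rather than a limit, with an at least 1.3-fold lower number from compound 3 to compound 4 (0.11 log units; that floor lies within the scatter). Against thiophen-2-yl in place of 4-(trifluoromethyl)phenyl the result is an at least 1.3-fold lower number from compound 2 to compound 4 (0.11 log units; that floor lies within the scatter), and adding the (thiophen-2-yl)sulfonyl group to the nitrogen gives an at least 1.3-fold lower number from compound 1 to compound 4 (0.11 log units; that floor lies within the scatter). Each of these steps is only a floor, so its true size stays unknown, and most of the series remains at a limit: the limit of > 50000 nM in this assay, at which 3 of the 4 values shown sit.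

Still open, going by these compounds, is whether a thiophen-2-yl carrying a chlorine or an amine on its ring, or a furan-2-yl in its place, would move the number beyond the scatter.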